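Swapping the aryl group in a thioether enone series

The compounds below may be only part of what the source reports. "The series", "measured", "known", "first", "only" and "open" are said of these compounds alone.

Compound 1 `COc1ccc(/C=C(/Sc2ccc(C)cc2)C(=O)c2ccc(Cl)cc2)cc1O` — 1000 nM
Compound 2 `COc1ccc(/C=C(/SCc2ccc(Cl)cc2)C(=O)c2ccc(Br)cc2)cc1` — 10000 nM

In a functional assay on DU-145 cells (Homo sapiens) for inhibition, read by trypan blue exclusion, with a stated time of 96 h (a higher number here means a weaker inhibitor of growth, a lower number a stronger inhibitor of growth), compound 2 gives 10000 nM, the highest of the two numbers measured; the nearest is compound 1, which gives a lower number, and this gap lies beyond the scatter. Within the data shown here, the two differ in several places, so their values show only that compound 2 is the weaker inhibitor of growth of the pair.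

Compound 3 `Cc1ccsc1/C=C(/SCc1ccc(Cl)cc1)C(=O)c1ccc(Br)cc1` keeps the thioether and carbonyl portions of compound 2 and changes one group:

3-methylthiophen-2-yl in place of 4-methoxyphenyl on a double-bonded chain carbon bound to a double-bonded chain carbon

Among the measured compounds shown here, no pair that differs in one place has been measured, so there is nothing to say how such a change moves the numbers in this assay. The expected step from compound 2 to compound 3 is therefore no change at the digits printed from compound 2 to compound 3 (within the scatter), no larger than the scatter in either direction. Compound 3 is expected to give 10000 nM, with a range from 3000 nM to 40000 nM.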

Compound 3, concentration for 50% growth inhibition: 25000 nM
Compound 3: middle estimate off by 2.5-fold (0.40 log units), on the low side, within the range that was stated.
By their numbers in this assay, from the lowest: compound 1; then compound 2; then compound 3.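

In this assay, among these compounds, the swap of 4-methoxyphenyl for 3-methylthiophen-2-yl gives the first step that can be read at a single place, a 2.5-fold higher number from compound 2 to compound 3 (0.40 log units; beyond the scatter), so this position on a double-bonded chain carbon bound to a double-bonded chain carbon does affect the number, though only modestly. The two groups have the same printed counts of hydrogen-bond donors and acceptors, so those counts do not separate them, yet the values still differ beyond the scatter. Nothing measured here accounts for the step.

The single swap changes the ring size, the hetero atom and the methyl and methoxy groups together, and the compounds shown cannot tell these apart. As far as these compounds go, how a plain thiophen-2-yl, a furan-2-yl or a 4-dimethylaminophenyl group would read at this place remains open.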